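A few compounds are considered here, and "the series" means these few. Any claim that something is new, unique, unknown or untested is made for them only; others in the source may bear on it.

Measured so far in a functional assay on HeLa cells (Homo sapiens) for antiproliferative activity, read by MTT assay, with a stated time of 48 h; on this read-out higher numbers stand for weaker inhibition and lower numbers for stronger inhibition:
- compound 1 `COc1cc(-c2nnc3c(OC(C)C)cc(-c4ccc5c(ccn5C)c4)cn23)cc(OC)c1OC` gives 503 nM
- compound 2 `COc1cc(-c2nnc3c(OC4COC4)cc(-c4ccc5c(ccn5C)c4)cn23)cc(OC)c1OC` gives 214 nM
- compound 3 `COc1cc(-c2nnc3c(OC4CCC4)cc(-c4ccc5c(ccn5C)c4)cn23)cc(OC)c1OC` gives 177 nM

Compound 3 sits at the low end of these numbers, level within the scatter with compound 2 and clear of compound 1. In compound 4 `CCCN1CC(Oc2cc(-c3ccc4c(ccn4C)c3)cn3c(-c4cc(OC)c(OC)c(OC)c4)nnc23)C1` the change is 1-propylazetidin-3-yl in place of cyclobutyl on an oxygen on an aromatic ring with 1-propylazetidin-3-yl in place of cyclobutyl on an oxygen on an aromatic ring. Bearing on this are a 2.4-fold lower number from compound 1 to compound 2 (0.37 log units; beyond the scatter) and a 2.8-fold lower number from compound 1 to compound 3 (0.45 log units; beyond the scatter) as modest steps and a 1.2-fold lower number from compound 2 to compound 3 (0.08 log units; within the scatter) within the scatter. Going by the values given here, no measured compound carries 1-propylazetidin-3-yl, so the expectation stays loose. An estimated step of a 1.6-fold higher number from compound 3 to compound 4 (0.20 log units; within the scatter) is expected, small and towards weaker inhibition. The estimate for compound 4 is 280 nM with a range of 90 nM to 850 nM expected.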

Compound 4, half-maximal inhibitory concentration: 211 nM
Estimate against measurement, compound 4: 1.3-fold (0.12 log units) above; the range from low to high includes it.
By their numbers in this assay, from the lowest: compounds 3, 4 and 2 (each within the scatter of the next); then compound 1.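

In this assay, the position on the oxygen accepts 1-propylazetidin-3-yl, with its ring nitrogen and propyl chain: a 1.2-fold higher number from compound 3 to compound 4 (0.08 log units; within the scatter) and a 1.0-fold lower number from compound 2 to compound 4 (0.01 log units; within the scatter) both lie within the scatter. The replacement of isopropyl also holds for this larger group, with a 2.4-fold lower number from compound 1 to compound 4 (0.38 log units; beyond the scatter) beyond the scatter, so compounds 2, 3 and 4 all stand clear of compound 1. No data are at hand on what lies behind these numbers. Left open is whether a free amine, a carboxylic acid or a longer chain on the ring nitrogen would keep the number at this level.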